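Removing the isopropoxy group from compound 2

The source may hold more compounds than are shown below. What is called first, only, known or untested is meant among the compounds shown, and "the series" means these compounds.

Measured compounds:
compound 1 `C1=C(c2cccnc2)C[C@@H]2CNC[C@H]1C2` gives 23 nM in an in vitro assay on SH-SY5Y cells for displacement of a labelled ligand from Neuronal acetylcholine receptor; alpha3/beta4 (Homo sapiens); a higher number here means a weaker inhibitor, a lower number a stronger inhibitor
compound 2 `CC(C)Oc1cncc(C2=CC3CNCC(C2)C3)c1` gives 4.8 nM in this assay

Compound 2 has the lowest number of the two in this assay; the nearest neighbour is compound 1, whose number is higher by a margin beyond the scatter. Going by the values given here, no pair of measured compounds differs in only one place, so no single-change step is available from the measured data.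

Compound 3 `C1=C(c2cccnc2)CC2CNCC1C2` is to be measured in this assay. It differs from compound 2 as follows: hydrogen in place of isopropoxy on an aromatic carbon. Compound 3 carries the same atoms as compound 1, drawn without stereochemical assignment, so the value of compound 1 in this assay, 23 nM, is the most direct guide.

The step from compound 2 to compound 3 in this assay is therefore expected to be upward, a 4.6-fold higher number from compound 2 to compound 3 (0.66 log units; beyond the scatter), beyond the scatter, because compound 1 gives 23 nM. For compound 3 in this assay the estimate is 22 nM, with a range from 8 nM to 60 nM.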

Compound 3, inhibition constant: 12 nM
Beside the measured number, compound 3's estimate is 1.8-fold (0.26 log units) above it; measured number inside the range.
By their numbers in this assay, from the lowest: compound 2; then compounds 3 and 1 (each within the scatter of the next).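

Hydrogen in place of isopropoxy on an aromatic carbon, two atoms from the ring nitrogen, gives in this assay a 2.5-fold higher number from compound 2 to compound 3 (0.40 log units; beyond the scatter), the first single-change reading at this position. The step is modest but beyond the scatter, so this position carries isopropoxy without loss in this assay, and the isopropoxy compound keeps the lower number. The second step, a 1.9-fold lower number from compound 1 to compound 3 (0.28 log units; within the scatter), lies within the scatter, so the drawn configuration gives no readable separation, and the comparison with the unsubstituted compounds rests on this caveat about the only difference between them: the fact that one of compounds 1 and 3 is drawn with a defined configuration and the other without, at the place where they differ

Open, as far as these compounds go, is whether the lower number of compound 2 belongs to the ether oxygen or to the branched carbon part of isopropoxy, a question that methoxy, an isopropyl group or a primary amine on the same aromatic carbon would help to separate. Also open is how the configuration of the shared core bears on these numbers, since compound 2 and compound 3 are both drawn without one and a single-change comparison between defined forms of the isopropoxy compound is not among those shown.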